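The compounds below may be only part of what the source reports. "The series", "measured", "known", "first", "only" and "open" are said of these compounds alone.

Measured in a toxicity assay on HEK293 cells (Homo sapiens) for inhibition, read by resazurin assay, with a stated time of 24 h (a lower number here means that less compound is tolerated, a higher number that more compound is tolerated), all three values being limits:

- Compound 1 `O=C(NCc1cccc(OC(F)(F)F)c1)c1ncc([N+](=O)[O-])[nH]1`: > 100000 nM
- Compound 2 `NC(=O)c1nc([N+](=O)[O-])cn1Cc1cccc(OC(F)(F)F)c1`: > 100000 nM
- Compound 3 `NC(=O)c1nc([N+](=O)[O-])cn1Cc1ccccn1`: > 100000 nM

Compound 3 has no number of its own and stands with the other two: the limit of > 100000 nM in this assay, at which 3 of the 3 values shown sit. Compound 4 `NC(=O)c1nc([N+](=O)[O-])cn1CC1CCCCC1` differs from it by cyclohexyl in place of pyridin-2-yl on a saturated chain carbon bound to an aromatic nitrogen. Within the data shown here, the series offers no measured step to scale this change. The expectation rests on compound 3, whose limit is > 100000 nM. In this assay, the expected change is a number no higher from compound 3 to compound 4 (the limit leaves the size open), with no direction and nothing beyond the scatter. Compound 4 is estimated at 100000 nM, with an expected range of 50000 nM to 200000 nM.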

Compound 4, half-maximal cytotoxic concentration: > 100000 nM
Compound 4 ended at the assay's limit; the forecaster's own chance of this, stated with the estimate: 80%; the middle value sits exactly at the limit.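

In this assay compound 4 gives > 100000 nM, a limit; compound 3 also stands at a limit, so no step can be read between compound 3 and compound 4. The compounds shown leave open whether any structural change alters the half-maximal cytotoxic concentration: the limit of > 100000 nM in this assay, at which 4 of the 4 values shown sit.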